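The source may hold more compounds than are shown below. What is called first, only, known or untested is meant among the compounds shown, and "the series" means these compounds.

Measured in an ADME assay on HepG2 cells (Homo sapiens) for cytotoxicity, read by MTT assay, with a stated time of 24 h; a higher number here means that more compound is tolerated, a lower number that less compound is tolerated:
- Compound 1 `CC1Cn2cc([N+](=O)[O-])nc2O1`: > 500000 nM, a limit
- Compound 2 `CC1Cn2c(nc([N+](=O)[O-])c2Br)O1`: 20100 nM
- Compound 3 `CC1Cn2c(nc([N+](=O)[O-])c2-c2ccccc2)O1`: > 500000 nM, a limit

Compound 3 gives > 500000 nM, which is a limit and not a number. This is the limit of > 500000 nM in this assay, at which 2 of the 3 values shown sit.

Compound 4 `Cc1ccc(-c2c([N+](=O)[O-])nc3n2CC(C)O3)s1` carries 5-methylthiophen-2-yl in place of phenyl on an aromatic carbon.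

Two measured steps at this same place bear on it. Bromo in place of hydrogen gave a large drop, an at least 24-fold lower number from compound 1 to compound 2 (1.39 log units; beyond the scatter), and phenyl in place of bromo gave a large rise, an at least 24-fold higher number from compound 2 to compound 3 (1.39 log units; beyond the scatter). Going by the values given here, no measured step swaps one aromatic ring for another, and compound 4 carries no bromo, so compound 4 is expected to stay close to compound 3 at > 500000 nM.

The expected step is small, an at least 1.2-fold lower number from compound 3 to compound 4 (0.09 log units; that floor lies within the scatter), and none beyond the scatter is expected. For compound 4 the estimated value is 400000 nM, with an expected range of 100000 nM to 700000 nM.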

Compound 4, half-maximal cytotoxic concentration: > 250000 nM
Compound 4: no number, only a limit; the forecaster's own chance of this, stated with the estimate: 60%; the middle value is on the limit's open side.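

In this assay compound 4 gives > 250000 nM, which is a limit and not a number: the limit of > 250000 nM in this assay, at which 1 of the 4 values shown sits. Phenyl is thus not the only aromatic ring on this carbon that avoids the low number seen with bromo, since 5-methylthiophen-2-yl in place of bromo gives an at least 12-fold higher number from compound 2 to compound 4 (1.09 log units; beyond the scatter). The steps to compound 4 from compound 1 and from compound 3 cannot be read, as both ends of each are limits, so phenyl and 5-methylthiophen-2-yl cannot be ranked.

The compounds shown leave open whether an amine or a longer carbon chain on this carbon would be tolerated as well. They also leave open whether chloro would bring the same drop as bromo.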